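A few compounds are considered here, and "the series" means these few. Any claim that something is new, unique, unknown or untested is made for them only; others in the source may bear on it.

Compound 1 `COC(=O)[C@@]1(C)CC[C@@H]2C3=C1CC[C@@H](C)[C@]3(C)C[C@@H]1c3cc(Br)ccc3N[C@H]21`: 40000 nM
Compound 2 `COC(=O)[C@@]1(C)CC[C@@H]2C3=C1CC[C@@H](C)[C@]3(C)C[C@@H]1c3cc(Cl)ccc3N[C@H]21`: 35000 nM

In a functional assay on A549 cells (Homo sapiens) for inhibition, read by sulforhodamine B assay, with a stated time of 48 h (a lower number here means a stronger inhibitor of growth, a higher number a weaker inhibitor of growth), compound 2 gives 35000 nM, and it stands together with compound 1, the two numbers lying within the scatter of each other. Compound 3 `COC(=O)[C@@]1(C)CC[C@@H]2C3=C1CC[C@@H](C)[C@]3(C)C[C@@H]1c3cc(F)ccc3N[C@H]21` differs from compound 2 by fluoro in place of chloro on an aromatic carbon. Within the data shown here, the one measured step that bears on exchanging one halogen for another is a 1.1-fold lower number from compound 1 to compound 2 (0.06 log units; within the scatter), which stayed within the scatter. On that basis no change beyond the scatter is expected in this assay, so the step is estimated as no change at the digits printed from compound 2 to compound 3 (within the scatter). Compound 3 is therefore expected to give about 35000 nM, in a range from 15000 nM to 80000 nM.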

Compound 3, concentration for 50% growth inhibition: 25000 nM
Beside the measured number, compound 3's estimate is 1.4-fold (0.15 log units) above it; the measured number falls inside the stated range.
By their numbers in this assay, from the lowest: compounds 3, 2 and 1 (each within the scatter of the next).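

In this assay, fluoro in place of chloro on this aromatic carbon gives a 1.4-fold lower number from compound 2 to compound 3 (0.15 log units; within the scatter), and fluoro in place of bromo gives a 1.6-fold lower number from compound 1 to compound 3 (0.20 log units; within the scatter). Even the widest exchange shown among these halogens therefore stays within the scatter, so compounds 1, 2 and 3 cannot be told apart in this assay. No measurement shown here accounts for this result. As far as these compounds go, whether an amine, a methoxy group or a nitrile on this carbon would move the number beyond the scatter remains open, as does the effect of replacing the methyl ester on the shared core with a carboxylic acid.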